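The source may report more compounds than this note shows. Statements on the series, on what has been measured and on what is new or still open speak of the compounds shown alone.

Series notes. In a functional assay on RAW264.7 cells (Mus musculus) for inhibition, read by Griess assay, with stated times of 2 h and 24 h (a higher number here means a weaker inhibitor, a lower number a stronger inhibitor), compound 1 `COc1ccc([C@@H]2CC(=O)c3c(O)cc(OCc4cn(Cc5ccccc5F)nn4)cc3O2)cc1O` gives 7320 nM. Going by the values given here, compound 2 `COc1ccc([C@@H]2CC(=O)c3c(O)cc(OCc4cn(Cc5ccc(F)cc5)nn4)cc3O2)cc1O` gives 15100 nM and stands highest of the two numbers measured so far. Among the compounds with values here, the only step between the measured compounds is a 2.1-fold higher number from compound 1 to compound 2 (0.31 log units; beyond the scatter), an exchange of 2-fluorophenyl for 4-fluorophenyl on a saturated chain carbon bound to an aromatic nitrogen.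

Compound 3 `COc1ccc([C@@H]2CC(=O)c3c(O)cc(OCc4cn(Cc5cccc(C#N)c5)nn4)cc3O2)cc1O` is not yet measured in this assay; it differs from compound 2 by 3-cyanophenyl in place of 4-fluorophenyl on a saturated chain carbon bound to an aromatic nitrogen. Within the data shown here, the measured step of a 2.1-fold higher number from compound 1 to compound 2 (0.31 log units; beyond the scatter) bears on it only loosely, since it concerns a fluorine on the same phenyl and was modest; no measured pair contains a nitrile, so that part of the change has no precedent. The expected step is therefore small, a 1.3-fold lower number from compound 2 to compound 3 (0.10 log units; within the scatter), with either direction open. Compound 3 is estimated in this assay at 12000 nM, in a range from 5000 nM to 30000 nM.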

Compound 3, half-maximal inhibitory concentration: 18000 nM
Compound 3: the middle estimate sits 1.5-fold (0.18 log units) below what was measured; the measured number falls inside the stated range.
By their numbers in this assay, from the lowest: compound 1; then compounds 2 and 3 (each within the scatter of the next).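

At the place on a saturated chain carbon bound to an aromatic nitrogen, 3-cyanophenyl and 4-fluorophenyl cannot be told apart in this assay with a 1.2-fold higher number from compound 2 to compound 3 (0.08 log units; within the scatter) as the whole of the step. Compound 1 keeps the lowest number of the three, with a 2.5-fold higher number from compound 1 to compound 3 (0.39 log units; beyond the scatter) alongside the earlier step, so a fluorine alone does not set the number: the 4-fluorophenyl of compound 2 groups with the 3-cyanophenyl of compound 3, not with the 2-fluorophenyl of compound 1. No measurement at hand offers a reason for this grouping.

On these data alone, whether other groups in the position held by fluorine in compound 1 would also give a lower number remains open. Also open, as far as these compounds go, is what an amine or a carboxylic acid on the phenyl would give, or a longer chain in place of the saturated chain carbon.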